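Chloro addition on the trifluoromethylphenyl urea of compound 2

This account rests on a few compounds, and the source may have more. Where it says the series, first, only, none or still open, it means among the compounds named here.

Measured compounds:
compound 1 `COc1cc2cc(Oc3ccc(NC(=O)Nc4ccc(C)cc4)cc3)c(C)nc2cc1OC`: 102%
compound 2 `COc1cc2cc(Oc3ccc(NC(=O)Nc4cccc(C(F)(F)F)c4)cc3)c(C)nc2cc1OC`: 26.7%

In a functional assay on DU-145 cells (Homo sapiens) for inhibition, read by sulforhodamine B assay, with a stated time of 48 h, tested at 10 uM (on this read-out lower numbers stand for a stronger effect and higher numbers for a weaker effect at the one concentration tested), compound 1 gives 102%. In this assay compound 2 gives 26.7%, the lowest of the two numbers in hand; its nearest neighbour is compound 1, and the step of a number 75.3 percentage points lower from compound 1 to compound 2 (beyond the scatter) lies beyond the scatter. That step came from 3-(trifluoromethyl)phenyl in place of 4-methylphenyl on an amide-type nitrogen, a change of the whole aryl group.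

Compound 3 `COc1cc2cc(Oc3ccc(NC(=O)Nc4ccc(Cl)c(C(F)(F)F)c4)cc3)c(C)nc2cc1OC` is not yet measured in this assay. It differs from compound 2 by chloro in place of hydrogen on an aromatic carbon. For the measured compounds named here, no measured step concerns a chloro entering ortho to a trifluoromethyl group on this ring; the only step known, from compound 1 to compound 2, bears on a different change and gives no direct reading for the chloro. With compound 2 already at 26.7%, a step of no size beyond the scatter, or a modest further lowering, is expected in this assay.

Compound 3 is therefore expected to give about 22%, within 8% to 40%, an estimated step of a number 4.7 percentage points lower from compound 2 to compound 3 (within the scatter).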

Compound 3, a percentage reported as activity, at one concentration (the size of the read-out at that concentration, not a potency): 12.7%
Compound 3: the middle estimate sits 9.3 percentage points above what was measured; the measured number falls inside the stated range.
By their numbers in this assay, from the lowest: compound 3; then compound 2; then compound 1.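

In this assay, chloro in place of hydrogen on an aromatic carbon, ortho to the trifluoromethyl group and para to a large group, gives a number 14 percentage points lower from compound 2 to compound 3 (beyond the scatter). The earlier step exchanged the whole aryl group, whereas this one isolates a single place on the ring and shows that the read-out can move further down after the 3-(trifluoromethyl)phenyl urea is in place. Across the combined aryl change, 4-chloro-3-(trifluoromethyl)phenyl in place of 4-methylphenyl gives a number 89.3 percentage points lower from compound 1 to compound 3 (beyond the scatter), leaving compound 3 with the lowest number of the three; no measurement in hand accounts for either step.

From the compounds shown here alone, it remains open whether this lowering is specific to chloro or would also follow from fluoro, bromo, methyl or methoxy at the same place, ortho to the trifluoromethyl group. Also unresolved are whether chloro would give a similar step without the trifluoromethyl group, and whether the order at this one concentration would hold in a full concentration series.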